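The source may report more compounds than this note shows. Statements on the series, on what has been measured and on what is new or still open speak of the compounds shown alone.

Measured compounds:
compound 1 `O=[N+]([O-])c1ccccc1CNc1cccc2[nH]ncc12`, 17000 nM
compound 2 `N#Cc1cc(NCc2ccccc2[N+](=O)[O-])c2cn[nH]c2c1`, > 100000 nM
compound 3 `O=C(O)c1cccc(CNc2cc(C(F)(F)F)cc3[nH]ncc23)c1`, 1690 nM

In an assay for inhibition of Tryptophan 2,3-dioxygenase (Homo sapiens), with stated times of 10 min and 60 min (a lower number here means a stronger inhibitor, a higher number a weaker inhibitor), compound 2 gives only a limit, > 100000 nM, which is the upper boundary the assay reports rather than a measured number (the limit of > 100000 nM in this assay, at which 1 of the 3 values shown sits). Compound 1 carries a hydrogen where compound 2 carries a cyano group. Compound 1 gives 17000 nM, and compound 3, a differently built analogue with a carboxylic acid and a trifluoromethyl group, gives 1690 nM.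

The step from compound 2 to compound 4 `O=[N+]([O-])c1ccccc1CNc1cc(Br)cc2[nH]ncc12` is bromo in place of cyano on an aromatic carbon. Going by the values given here, the only measured change at that position is an at least 5.8-fold higher number from compound 1 to compound 2 (0.76 log units; beyond the scatter), where adding cyano to the unsubstituted core of compound 1 pushed the number beyond the limit. Replacing that cyano with bromo undoes the one change that was shown to weaken inhibition and introduces a group for which no direct comparison exists here; the value of compound 3, which carries a trifluoromethyl group at the same place on its own core, shows that a halogen-containing substituent there can sit well below the limit.

Compound 4 is therefore expected to return into the measurable range, with an estimated step of an at least 5.0-fold lower number from compound 2 to compound 4 (0.69 log units; beyond the scatter). The estimate for compound 4 in this assay is 20000 nM, within a range from 5000 nM to 90000 nM.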

Compound 4, half-maximal inhibitory concentration: 39000 nM
Estimate against measurement, compound 4: 2.0-fold (0.29 log units) below, and the stated range covers the measured number.
By their numbers in this assay, from the lowest: compound 3; then compound 1; then compound 4. At a limit, above all of these: compound 2.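

In this assay, bromo on this aromatic carbon gives a 2.3-fold higher number from compound 1 to compound 4 (0.36 log units; beyond the scatter), so on this core a substituent at this place need not push the number to the limit, although bromo still does worse than plain hydrogen. Exchanging the nitrile for bromo gives an at least 2.5-fold lower number from compound 2 to compound 4 (0.40 log units; beyond the scatter), which places the three groups in order on the shared core: hydrogen gives the lowest number, then bromo, then cyano, so the weakening depends on which group is present and is not simply a result of substituting this carbon. That step has only a minimum size, and the value of compound 2 is a limit rather than a number: the limit of > 100000 nM in this assay, at which 1 of the 4 values shown sits.

The compounds shown leave open whether any group at this place can bring the number below that of hydrogen, a question that an amine or a methoxy group on the same core would help to answer. Compound 3 differs from the others in more than one place, so what its trifluoromethyl group contributes cannot be separated from the contribution of its carboxylic acid.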